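The source may hold more compounds than are shown below. What is called first, only, known or untested is meant among the compounds shown, and "the series" means these compounds.

Going by the values given here, compound 2 (`C=C1CC[C@@H]2[C@](C)(CO)[C@H](OC(C)=O)CC[C@@]2(C)[C@@H]1C/C=C1\C=COC1=O`) gives 872000 nM in an ADME assay on HepG2 2.2.15 cells (Homo sapiens) for cytotoxicity, read by MTT assay (on this read-out higher numbers stand for lower toxicity in this test and lower numbers for higher toxicity in this test), and so holds the higher of the two numbers so far, with compound 1 (`C=C1CC[C@@H]2[C@](C)(CO)[C@H](OC(=O)/C=C/c3ccccc3)CC[C@@]2(C)[C@@H]1C/C=C1\C=COC1=O`) at 179000 nM as the only other reading. Among the compounds with values here, compound 3 (`C=C1CC[C@@H]2[C@](C)(CO)[C@H](OC(=O)CCCC)CC[C@@]2(C)[C@@H]1C/C=C1\C=COC1=O`) differs from compound 2 by propyl in place of hydrogen on a saturated chain carbon bound to a carbonyl carbon as its one change: propyl in place of hydrogen on a saturated chain carbon bound to a carbonyl carbon. Within the data shown here, one measured step bears on this, a 4.9-fold higher number from compound 1 to compound 2 (0.69 log units; beyond the scatter) for methyl in place of 2-phenylethenyl on a carbonyl carbon. Compound 1, carrying the larger group, sits lower, but the two changes are not the same, so that step guides direction more than size. A smaller step towards lower numbers is therefore expected in this assay and it may lie close to the scatter. The expected change is a 1.9-fold lower number from compound 2 to compound 3 (0.29 log units; within the scatter) on this estimate. Compound 3 is estimated at 450000 nM (expected range 200000 nM to 950000 nM).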

Compound 3, half-maximal cytotoxic concentration: 126000 nM
Estimate against measurement, compound 3: 3.6-fold (0.55 log units) above; the measured number lies below the stated range.
By their numbers in this assay, from the lowest: compounds 3 and 1 (each within the scatter of the next); then compound 2.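

In this assay, this position responds to a saturated chain as well as to the 2-phenylethenyl group: going from methyl to butyl on the carbonyl carbon gives a clear drop (a 6.9-fold lower number from compound 2 to compound 3 (0.84 log units; beyond the scatter)). Butyl and 2-phenylethenyl cannot be told apart here (a 1.4-fold lower number from compound 1 to compound 3 (0.15 log units; within the scatter)), so among these three compounds the lower numbers do not depend on a ring in this group, and only the acetyl compound stands apart. No supporting measurement is available to explain this shift.

The compounds shown leave open how the number changes with chain length, both for ethyl or propyl chains between methyl and butyl and for a longer chain such as octyl. They also leave open whether an amine or a carboxylic acid at the end of the chain would bring the number back up.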